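Nitro for methyl on an aryloxymethyl oxazoline core

The source may report more compounds than this note shows. Statements on the series, on what has been measured and on what is new or still open speak of the compounds shown alone.

Compound 1, `Cc1ccccc1OCC1=NCCO1`, gives 10% in a toxicity assay on the whole organism with Rattus norvegicus as the target, at a dose of 100 mg/kg by the oral route; a lower number here means a weaker effect, a higher number a stronger effect of the compound at the dose given. Compound 3, `O=[N+]([O-])c1ccccc1OCC1=NCCO1`, carries nitro in place of methyl on an aromatic carbon and gives 20% in this assay, so that the change makes a number 10 percentage points higher from compound 1 to compound 3 (within the scatter). Compound 2, `Cc1cccc(OCC2=NCCO2)c1`, gives 15% in this assay; the difference between the core of compound 2 and the core of compound 1 is not broken down here. Compound 4, `O=[N+]([O-])c1cccc(OCC2=NCCO2)c1`, is not yet measured and differs from compound 2 by nitro in place of methyl on an aromatic carbon. This is the same kind of change as that from compound 1 to compound 3, but the place is not the same: there the nitro stands ortho to a group of 7 heavy atoms, here meta to such a group. Resting on a number 10 percentage points higher from compound 1 to compound 3 (within the scatter), the step is expected to be a number 10 percentage points higher from compound 2 to compound 4 (within the scatter). Compound 4 is therefore estimated to give about 25% in this assay.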

Compound 4, a percentage reported as activity, at one dose (the size of the read-out at that dose, not a potency): 45%
Estimate against measurement, compound 4: 20 percentage points below; measured number outside the range, above it.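

Nitro in place of methyl on an aromatic carbon gives a number 30 percentage points higher from compound 2 to compound 4 (beyond the scatter) in this assay. Carried from one core to the other, the change did not keep its size: the same change on two cores in this assay, a number 10 percentage points higher (within the scatter) from compound 1 to compound 3 and a number 30 percentage points higher (beyond the scatter) from compound 2 to compound 4, 20 percentage points apart, beyond the scatter of two such steps With only one pair on each core, this shows that the size of the step on one core cannot simply be transferred to the other, but it does not show what sets the two steps apart or how the change would behave on any further core.

The compounds shown leave open whether an amine or a carboxylic acid in place of the nitro on the core of compound 4 would give a step of similar size.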